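A Fluorophenyl for a Chloropyridine on the Thiourea Series

A few compounds are considered here, and "the series" means these few. Any claim that something is new, unique, unknown or untested is made for them only; others in the source may bear on it.

Compound 1 `Nc1ccccc1NC(=O)c1ccc(NC(=S)NCc2cccc(F)c2)cc1`: 5900 nM
Compound 2 `Nc1ccccc1NC(=O)c1ccc(NC(=S)NCc2ccc(Cl)nc2)cc1`: 6100 nM

For the measured compounds named here, in a functional assay on HCT-116 cells (Homo sapiens) for cytotoxicity, read by MTT assay, with a stated time of 72 h (on this read-out lower numbers stand for stronger inhibition and higher numbers for weaker inhibition), compound 2 stands level with compound 1, the only other measured compound. Compound 3 `Nc1ccccc1NC(=O)c1ccc(NC(=S)NCc2ccccc2F)cc1` differs from compound 2 as follows: 2-fluorophenyl in place of 6-chloropyridin-3-yl on a saturated chain carbon bound to an amide-type nitrogen. In words, 2-fluorophenyl takes the place of 6-chloropyridin-3-yl on a saturated chain carbon bound to an amide-type nitrogen. Going by the values given here, the one measured step bearing on this exchange, a 1.0-fold higher number from compound 1 to compound 2 (0.01 log units; within the scatter), links that same 6-chloropyridin-3-yl to a fluorophenyl group, so no shift beyond the scatter is expected. The expected step is a 1.1-fold lower number from compound 2 to compound 3 (0.02 log units; within the scatter). For compound 3 the estimated value is 5800 nM, with an expected range of 2900 nM to 11000 nM.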

Compound 3, half-maximal inhibitory concentration: 6300 nM
The estimate for compound 3 lay 1.1-fold (0.04 log units) below the measured number; low and high end bracket the measured number.
By their numbers in this assay, from the lowest: compounds 1, 2 and 3 (each within the scatter of the next).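

On the saturated chain carbon bound to an amide-type nitrogen, 2-fluorophenyl in place of 6-chloropyridin-3-yl gives a 1.0-fold higher number from compound 2 to compound 3 (0.01 log units; within the scatter) in this assay and so repeats the flat result of the first exchange. 2-Fluorophenyl in place of 3-fluorophenyl gives a 1.1-fold higher number from compound 1 to compound 3 (0.03 log units; within the scatter) as well, so where the fluorine sits on the phenyl ring makes no difference beyond the scatter in these compounds. Nothing at hand offers a reason for this level outcome.

Still open, as far as these compounds go, is whether a non-aromatic group here, such as cyclohexyl or morpholine, or a longer chain carrying the same rings would move the number beyond the scatter.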